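The source may hold more compounds than are shown below. What is called first, only, known or untested is meant among the compounds shown, and "the series" means these compounds.

Measured in an ADME assay on WI-38 cells (Homo sapiens) for cytotoxicity, read by MTT assay, with a stated time of 72 h; a higher number here means a weaker inhibitor, a lower number a stronger inhibitor:
- compound 1 `O=C(CCc1cccc2c1B(O)OC2)Nc1ccccc1`: 30000 nM
- compound 2 `O=C(CCc1cccc2c1B(O)OC2)Nc1nccs1`: > 100000 nM, a limit of the assay

Within the data shown here, compound 1 carries the only true number so far. For compound 2 the result is the limit of > 100000 nM in this assay, at which 1 of the 2 values shown sits.

Compound 3 `O=C(CCc1cccc2c1B(O)OC2)Nc1cccc(-c2ccccc2)c1` keeps the core and amide of compound 1 and changes the phenyl on the amide nitrogen: phenyl in place of hydrogen on an aromatic carbon. Among the measured compounds shown here, the one measured step, an at least 3.3-fold higher number from compound 1 to compound 2 (0.52 log units; beyond the scatter), concerns the same group on the amide nitrogen, but it replaces that group rather than adding to it. It therefore gives a direction only loosely and no direct size. A small step toward a lower number in this assay, not clearly beyond the scatter, is expected, opposite to the rise seen in an at least 3.3-fold higher number from compound 1 to compound 2 (0.52 log units; beyond the scatter). The expected step is a 2.0-fold lower number from compound 1 to compound 3 (0.30 log units; within the scatter). For compound 3 the estimated value is 15000 nM, with an expected range of 4000 nM to 60000 nM.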

Compound 3, half-maximal inhibitory concentration: 12000 nM
Beside the measured number, compound 3's estimate is 1.3-fold (0.10 log units) above it, within the range that was stated.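

In this assay, phenyl in place of hydrogen on an aromatic carbon, meta to a large group, gives a 2.5-fold lower number from compound 1 to compound 3 (0.40 log units; beyond the scatter); this is the only change shown that adds to the group on the amide nitrogen rather than replacing it. The replacement gave an at least 3.3-fold higher number from compound 1 to compound 2 (0.52 log units; beyond the scatter), so changes at this group have now moved the number in both directions, each by a step beyond the scatter. The upward step rests on a limit for compound 2, not on a true number: the limit of > 100000 nM in this assay, at which 1 of the 3 values shown sits.

From the compounds shown here alone, whether the step needs a whole ring remains open, since a methyl or an amine on the same aromatic carbon could show otherwise. Also open, going by these compounds, is whether phenyl on a different aromatic carbon of that ring, or a longer chain between the amide and the core, would move the number the same way.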